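Swapping the dibrominated aniline for a fused ring

The compounds below may be only part of what the source reports. "The series", "measured", "known", "first", "only" and "open" are said of these compounds alone.

Compound 1 `COc1cc(N)c(Cl)cc1C(=O)CCC1CCN(CCNS(=O)(=O)c2ccc(N)cc2)CC1`: 7%
Compound 2 `COc1cc(N)c(Cl)cc1C(=O)CCC1CCN(CCNS(=O)(=O)c2ccc(NC(C)=O)cc2)CC1`: 7%
Compound 3 `COc1cc(N)c(Cl)cc1C(=O)CCC1CCN(CCNS(=O)(=O)c2cc(Br)c(N)c(Br)c2)CC1`: 52%

Three compounds share a core and differ only in the ring attached to the sulfonyl sulfur. In an assay on HEK293 cells for displacement of a labelled ligand from 5-hydroxytryptamine receptor 6 (Homo sapiens), with a stated time of 60 min, tested at 0.01 uM, in the presence of a further agent that is not named here (on this read-out lower numbers stand for a weaker effect and higher numbers for a stronger effect at the one concentration tested), compound 3 stands highest, with compound 1 and compound 2 both well below it. The step of no change at the digits printed from compound 1 to compound 2 (within the scatter) shows that acetylating the aromatic nitrogen changes nothing. The steps of a number 45 percentage points higher from compound 1 to compound 3 (beyond the scatter) and a number 45 percentage points higher from compound 2 to compound 3 (beyond the scatter) show that the two bromines flanking the amino group carry the whole gain.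

Compound 4 `COc1cc(N)c(Cl)cc1C(=O)CCC1CCN(CCNS(=O)(=O)c2ccc3c(c2)NC(=O)CO3)CC1` takes a different route: a group of 11 heavy atoms (8 carbon, 1 nitrogen, 2 oxygen; one six-membered non-aromatic ring with 2 hetero atoms, one six-membered aromatic ring of carbon only) in place of a group of 9 heavy atoms (6 carbon, 1 nitrogen, 2 bromine; one six-membered aromatic ring of carbon only), on a sulfonyl sulfur. The bromines leave and nothing like them enters; instead a second, non-aromatic ring is fused on. For the measured compounds named here, no measured step tests a fused ring here, so the guidance is limited to the loss of the bromines, which in the step to compound 3 were worth a large gain. The step of a number 37 percentage points lower from compound 3 to compound 4 (beyond the scatter) is therefore expected to be a clear drop. Compound 4 is estimated at 15%, within 3% to 40%.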

Compound 4, a percentage reported as inhibition, at one concentration (the size of the read-out at that concentration, not a potency): "not active" (no number reported)
No number was reported for compound 4, so the estimate cannot be set against anything.
By their numbers in this assay, from the lowest: compounds 1 and 2 (each within the scatter of the next); then compound 3.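

In this assay, for the compounds shown here, compound 4 stands as "not active" (no number reported) and so no step from compound 3 to compound 4 can be read. Nothing measured here offers an explanation for this result. The compounds shown leave open whether the fused ring itself or the loss of the two bromines shapes the read-out.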